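This account rests on a few compounds, and the source may have more. Where it says the series, first, only, none or still open, it means among the compounds named here.

The measured compounds, each read in an ADME assay on Vero cells (Chlorocebus sabaeus) for cytotoxicity, read by resazurin assay, with a stated time of 3 days; on this read-out higher numbers stand for weaker inhibition and lower numbers for stronger inhibition:

Compound 1, `CN(C)c1cc2[nH]c(C3CCCCC3)nc2cc1NC(=O)OCc1ccccc1`, is reported only as the limit > 100 ug/mL.
Compound 2, `CN(C)c1cc2[nH]c(C3CCCCC3)nc2cc1NC(=O)c1ccc(C(C)(C)C)cc1`, is reported only as the limit > 100 ug/mL.
Compound 3, `CN(C)c1cc2[nH]c(C3CCCCC3)nc2cc1NC(=O)c1cccs1`, is reported only as the limit > 100 ug/mL.

Compound 3 therefore has no number of its own in this assay, only a limit, and it stands exactly where the other two stand, at the limit of > 100 ug/mL in this assay, at which 3 of the 3 values shown sit. The three compounds share the same core and differ only in the group attached to the carbonyl carbon. Going by the values given here, with every value at the limit, none of the measured steps can be read: a step that the two limits leave unreadable from compound 1 to compound 2, a step that the two limits leave unreadable from compound 1 to compound 3 and a step that the two limits leave unreadable from compound 2 to compound 3 are each of unknown size.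

Compound 4, `Cc1ccc(C(=O)Nc2cc3nc(C4CCCCC4)[nH]c3cc2N(C)C)cc1`, is the next member of this set. Its change from compound 3 is 4-methylphenyl in place of thiophen-2-yl on a carbonyl carbon. Swapping one group on the carbonyl carbon for another has so far produced nothing readable among compound 1, compound 2 and compound 3, so no step beyond the scatter is anticipated here. The expected step for compound 4 is a number no higher from compound 3 to compound 4 (the limit leaves the size open). Compound 4 is estimated at 100 ug/mL, within 50 ug/mL to 200 ug/mL, and most probably it will again be reported only as a limit.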

Compound 4, half-maximal inhibitory concentration: > 100 ug/mL
Compound 4: only a limit was reported; the forecaster's own chance of this, stated with the estimate: 85%; the middle value sits exactly at the limit.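

In this assay compound 4 is reported only as a limit, > 100 ug/mL. Its steps from compound 1, compound 2 and compound 3 therefore cannot be read, and all four compounds stand together: the limit of > 100 ug/mL in this assay, at which 4 of the 4 values shown sit. The compounds shown leave open what real value any of them has in this assay, and whether the group on the carbonyl carbon alters it at all.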